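Ester and thiophene changes in one small series

The compounds below may be only part of what the source reports. "The series", "measured", "known", "first", "only" and "open" are said of these compounds alone.

Measured so far in an assay on membranes from CHO cells for displacement of a labelled ligand from adenosine receptor A1 (Homo sapiens), read by scintillation counting, with a stated time of 60 min, tested at 1 uM; a lower number here means less inhibition, a higher number more inhibition at the concentration tested (going by the name of the read-out):

- compound 1 `CC1=C(C(=O)OC(C)(C)C)C(c2cccs2)NC(=O)N1`: 26%
- compound 2 `CC1=C(C(=O)OCc2ccccc2)C(c2cccs2)NC(=O)N1`: 45%
- compound 3 `CC1=C(C(=O)OC(C)(C)C)C(c2ccsc2)NC(=O)N1`: 15%

Compound 4 `CC1=C(C(=O)OCc2ccccc2)C(c2ccsc2)NC(=O)N1` has not been measured in this assay.

Two changes run through the set. From compound 1 to compound 2 the ester is varied, (benzyl in place of tert-butyl on an oxygen next to a carbonyl group), and this gives a number 19 percentage points higher from compound 1 to compound 2 (beyond the scatter). From compound 1 to compound 3 the attachment of the thiophene is varied, (thiophen-3-yl in place of thiophen-2-yl on a saturated ring carbon), and this gives a number 11 percentage points lower from compound 1 to compound 3 (beyond the scatter). Compound 3 stands lowest of the three measured compounds, with both its steps beyond the scatter.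

Compound 4 carries the same ester change on the core of compound 3: benzyl in place of tert-butyl on an oxygen next to a carbonyl group. The two descriptions of the place of the change agree word for word, so the change from compound 3 to compound 4 is the same as that from compound 1 to compound 2; the two cores differ as described above under the change from compound 1 to compound 3.

The expectation for compound 4 rests on a single earlier instance. Because the ester change gave a number 19 percentage points higher from compound 1 to compound 2 (beyond the scatter), a step of similar size is expected here, a number 19 percentage points higher from compound 3 to compound 4 (beyond the scatter), though one pair is a thin basis and the step may differ on the core of compound 3. Compound 4 is therefore estimated at 34%, with a likely range from 20% to 48%.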

Compound 4, a percentage reported as inhibition, at one concentration (the size of the read-out at that concentration, not a potency): 57%
Beside the measured number, compound 4's estimate is 23 percentage points below it; the whole stated range lies below it.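

In this assay benzyl in place of tert-butyl again raises the number, giving a number 42 percentage points higher from compound 3 to compound 4 (beyond the scatter), so the direction of the ester change carries from the core of compound 1 to the core of compound 3, but its size does not: the same change on two cores in this assay, a number 19 percentage points higher (beyond the scatter) from compound 1 to compound 2 and a number 42 percentage points higher (beyond the scatter) from compound 3 to compound 4, 23 percentage points apart, beyond the scatter of two such steps

The thiophene change does not even keep its direction, giving a number 12 percentage points higher from compound 2 to compound 4 (beyond the scatter) on the benzyl ester, whereas it lowered the number on the tert-butyl ester: the same change on two cores in this assay, a number 11 percentage points lower (beyond the scatter) from compound 1 to compound 3 and a number 12 percentage points higher (beyond the scatter) from compound 2 to compound 4, 23 percentage points apart, beyond the scatter of two such steps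

The ester and the thiophene attachment therefore do not act as separate, additive increments in these compounds, and a step read on one core cannot be carried to another as a fixed amount, though this rests on one closed set of four compounds and shows neither the reason for the difference nor whether it extends to any other ester or core.

The compounds shown leave open whether the larger benzyl step on the thiophen-3-yl core also appears with a methyl or ethyl ester, a longer chain such as phenethyl, or an amide in place of the ester. They also leave open how the two thiophene attachments compare with a plain phenyl ring on the saturated ring carbon.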